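Pyridin-3-yl to Pyridin-4-yl: Expecting a Small Step

The compounds below may be only part of what the source reports. "The series", "measured", "known", "first", "only" and "open" are said of these compounds alone.

In a functional assay for inhibition, with Homo sapiens as the target (a lower number here means a stronger inhibitor, a higher number a weaker inhibitor), compound 1 (`COc1ccc2nc(COc3ccc4c(c3)c(SC(C)(C)C)c(CC(C)(C)C(=O)O)n4Cc3ccc(Cl)cc3)sc2c1`) gives 8 nM and compound 2 (`CC(C)(C)Sc1c(CC(C)(C)C(=O)O)n(Cc2ccc(Cl)cc2)c2ccc(OCc3cccnc3)cc12`) gives 8 nM at the digits shown, so compound 2 stands level with compound 1, its nearest neighbour. Compound 3 (`CC(C)(C)Sc1c(CC(C)(C)C(=O)O)n(Cc2ccc(Cl)cc2)c2ccc(OCc3ccncc3)cc12`) has the same atoms as compound 2, joined differently, with pyridin-4-yl in place of pyridin-3-yl on a saturated chain carbon bound to an oxygen on an aromatic ring. Among the measured compounds shown here, only one measured step touches that place (no change at the digits printed from compound 1 to compound 2 (within the scatter)), where pyridin-3-yl took the place of 6-methoxy-1,3-benzothiazol-2-yl without a shift beyond the scatter. For the measured compounds named here, no pyridin-4-yl compound has a measured value yet, so this evidence is thin. The expected step (no change at the digits printed from compound 2 to compound 3 (within the scatter)) therefore lies within the scatter, with no direction favoured. For compound 3 the estimated value is 8 nM (expected range 3 nM to 22 nM).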

Compound 3, half-maximal inhibitory concentration: 6 nM
Compound 3: middle estimate off by 1.3-fold (0.12 log units), on the high side; low and high end bracket the measured number.
By their numbers in this assay, from the lowest: compounds 3, 1 and 2 (each within the scatter of the next).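

In this assay, pyridin-4-yl in place of pyridin-3-yl gives a 1.3-fold lower number from compound 2 to compound 3 (0.12 log units; within the scatter), so at this place, on a saturated chain carbon bound to an oxygen on an aromatic ring, the two groups cannot be told apart. Pyridin-4-yl in place of 6-methoxy-1,3-benzothiazol-2-yl gives a 1.3-fold lower number from compound 1 to compound 3 (0.12 log units; within the scatter), which means that all three groups now read alike here, and a second pyridinyl group joins the first in matching the larger two-ring group. Nothing available explains why these numbers sit together.

Still open, from the compounds shown here alone, is whether pyridin-2-yl, or a plain phenyl ring with no ring nitrogen, would read the same at this place. Also open, going by these compounds, is whether a phenyl ring carrying an amine or a carboxylic acid would move the number beyond the scatter.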